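Cyclopropyl in place of chloro on the aryl ring

This account rests on a few compounds, and the source may have more. Where it says the series, first, only, none or still open, it means among the compounds named here.

Measured in an assay on cells for inhibition of Palmitoleoyl-protein carboxylesterase NOTUM variant C330S (Homo sapiens), read by fluorescence, with a stated time of 40 min; a higher number here means a weaker inhibitor, a lower number a stronger inhibitor:
compound 1 `Cc1cc(C(=O)O)c(C)n1-c1cccc(F)c1` gives 1500 nM
compound 2 `Cc1cc(C(=O)O)c(C)n1-c1cccc(Cl)c1C#N` gives 2000 nM
compound 3 `Cc1cc(C(=O)O)c(C)n1-c1cccc(Cl)c1` gives 430 nM

Compound 3 stands lowest of the three numbers, clear of the scatter against both others: a 3.5-fold lower number from compound 1 to compound 3 (0.54 log units; beyond the scatter) and a 4.7-fold lower number from compound 2 to compound 3 (0.67 log units; beyond the scatter). Compound 4 `Cc1cc(C(=O)O)c(C)n1-c1cccc(C2CC2)c1` is not yet measured; it differs from compound 3 in one place: cyclopropyl in place of chloro on an aromatic carbon. Among the compounds with values here, of the measured steps only the one from compound 1 to compound 3 bears on this, as it too exchanges one group for another on an aromatic carbon, and it was modest. Within the data shown here, no measured step shows a carbon ring in place of a halogen there. The expectation for compound 4 in this assay is therefore a step within the scatter or a small lowering, a 1.2-fold lower number from compound 3 to compound 4 (0.09 log units; within the scatter). The estimate for compound 4 is 350 nM, expected within 120 nM to 1200 nM.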

Compound 4, half-maximal inhibitory concentration: 580 nM
Compound 4: the middle estimate sits 1.7-fold (0.22 log units) below what was measured; the measured number falls inside the stated range.
By their numbers in this assay, from the lowest: compounds 3 and 4 (each within the scatter of the next); then compounds 1 and 2 (each within the scatter of the next).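

In this assay, within the data shown here, the exchange of chloro for cyclopropyl on this aromatic carbon gives a 1.3-fold higher number from compound 3 to compound 4 (0.13 log units; within the scatter), so a three-membered carbon ring can stand here in place of a halogen, which the earlier compounds did not show. The exchange of fluoro for cyclopropyl gives a 2.6-fold lower number from compound 1 to compound 4 (0.41 log units; beyond the scatter), so compound 4 joins compound 3 in separating from compound 1. No measurement on hand explains either step. Still open, as far as these compounds go, is whether a methoxy group, an amine or a longer chain on this carbon would stay level with chloro and cyclopropyl.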